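The source may hold more compounds than are shown below. What is called first, only, known or untested is meant among the compounds shown, and "the series" means these compounds.

Compound 1 `COc1cc(CC(C)C(=O)N2CCN(c3ccc(C(F)(F)F)cc3[C@@H](N)CC(C)C)CC2)ccc1Cl`, compound 2 `COc1ccc(OCC(=O)N2CCN(c3ccc(C(F)(F)F)cc3[C@@H](N)CC(C)C)CC2)cc1` and compound 3 `CCOc1cccc(CC(C)C(=O)N2CCN(c3ccc(C(F)(F)F)cc3[C@@H](N)CC(C)C)CC2)c1` have all been measured.

In an assay on HEK293 cells for displacement of a labelled ligand from Melanocortin receptor 4 (Homo sapiens) (on this read-out lower numbers stand for stronger inhibition and higher numbers for weaker inhibition), compound 1 gives 230 nM. In the same assay compound 2 gives 3800 nM, and compound 3 gives 2200 nM.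

Compound 3 stands second highest of the three numbers. Its nearest neighbour is compound 2, and the step of a 1.7-fold lower number from compound 2 to compound 3 (0.24 log units; within the scatter) lies within the scatter, so no order between these two can be read. Compound 1 is furthest away, and a 9.6-fold higher number from compound 1 to compound 3 (0.98 log units; beyond the scatter) lies beyond the scatter.

Compound 4 `Cc1cc(Cl)ccc1CC(C)C(=O)N1CCN(c2ccc(C(F)(F)F)cc2[C@@H](N)CC(C)C)CC1` is the next compound, and it differs from compound 3 in one place: 4-chloro-2-methylphenyl in place of 3-ethoxyphenyl on a saturated chain carbon, two bonds along the chain from a carbonyl carbon.

Of the measured steps, a 9.6-fold higher number from compound 1 to compound 3 (0.98 log units; beyond the scatter) is the one that bears on this change, since it exchanges the aryl group at the same place on the chain. Compound 1 carries a 4-chloro-3-methoxyphenyl group there, and compound 4 brings a chlorine back into the same kind of group in the form of 4-chloro-2-methylphenyl. The step of a 17-fold higher number from compound 1 to compound 2 (1.22 log units; beyond the scatter) changes a different part of the molecule and is less telling. A lower number than that of compound 3 is therefore expected, of modest size. Compound 4 is expected to give about 550 nM, with a range from 150 nM to 2000 nM. The expected step is a 4.0-fold lower number from compound 3 to compound 4 (0.60 log units; beyond the scatter).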

Compound 4, inhibition constant: 38 nM
Beside the measured number, compound 4's estimate is 14-fold (1.16 log units) above it, and the stated range ends above it.
By their numbers in this assay, from the lowest: compound 4; then compound 1; then compounds 3 and 2 (each within the scatter of the next).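

In this assay the aryl group on the saturated chain carbon, two bonds along the chain from a carbonyl carbon, proves able to carry far more than compounds 1 to 3 showed: a 58-fold lower number from compound 3 to compound 4 (1.76 log units; beyond the scatter) comes with 4-chloro-2-methylphenyl in place of 3-ethoxyphenyl. The chlorine alone does not settle the matter, since a 6.1-fold lower number from compound 1 to compound 4 (0.78 log units; beyond the scatter) separates two aryl groups that both hold it, 4-chloro-2-methylphenyl having replaced 4-chloro-3-methoxyphenyl, so the other group on the ring counts as well. On the carbonyl carbon, a 100-fold lower number from compound 2 to compound 4 (2.00 log units; beyond the scatter) goes with 1-(4-chloro-2-methylbenzyl)ethyl in place of (4-methoxyphenoxy)methyl, the widest step in the set, whereas a 1.7-fold lower number from compound 2 to compound 3 (0.24 log units; within the scatter) had given no sign that this exchange could reach so far.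

The compounds shown leave open how the methyl and the chlorine each contribute on their own, and what a fluorine, a nitrile or an amine in place of the chlorine would do at this place. Nothing in the data given explains why these steps take the sizes they do.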